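This account rests on a few compounds, and the source may have more. Where it says the series, first, only, none or still open, it means among the compounds named here.

Among the compounds with values here, in an in vivo ADME assay on the whole organism for pharmacokinetics, with Canis familiaris (Canis lupus familiaris) as the target (on this read-out higher numbers stand for wider distribution into tissues and lower numbers for narrower distribution), compound 3 (`Nc1noc2ccc(-n3nc(C(F)(F)F)c4c3C(=O)N(c3ccc(-c5ccccc5CN5CCC(O)CC5)cc3)CC4)cc12`) gives 1.4 L/kg, the lowest of the three numbers so far. Compound 2 (`Nc1noc2ccc(-n3nc(C(F)(F)F)c4c3C(=O)N(c3ccc(-c5ccccc5CN5CCCC5)cc3)CC4)cc12`) gives 5 L/kg, and compound 1 (`CN(C)Cc1ccccc1-c1ccc(N2CCc3c(C(F)(F)F)nn(-c4ccc5onc(N)c5c4)c3C2=O)c(F)c1`) gives 8.8 L/kg. Both gaps to compound 3 lie beyond the usual scatter.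

Compound 4 (`CN(C)Cc1ccccc1-c1ccc(N2CCc3c(C(F)(F)F)nn(-c4ccc5onc(N)c5c4)c3C2=O)cc1`) differs from compound 3 in one place: dimethylamino in place of 4-hydroxypiperidin-1-yl on a saturated chain carbon bound to an aromatic carbon. Put simply, dimethylamino stands in place of 4-hydroxypiperidin-1-yl on a saturated chain carbon bound to an aromatic carbon.

Within the data shown here, one measured step touches this place: a 3.6-fold lower number from compound 2 to compound 3 (0.55 log units; beyond the scatter), a modest change beyond the scatter, with 4-hydroxypiperidin-1-yl entering in place of pyrrolidin-1-yl. Compound 4 gives that group up again, so a rise of similar or somewhat larger size is expected. Compound 1 also carries dimethylamino at this place and reads 8.8 L/kg, but it is not identical to compound 4 elsewhere, so it is only a rough guide.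

The expected change is a 4.3-fold higher number from compound 3 to compound 4 (0.63 log units; beyond the scatter). For compound 4 the estimated value is 6 L/kg, with an expected range from 3 L/kg to 11 L/kg.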

Compound 4, volume of distribution at steady state: 4.5 L/kg
Compound 4: middle estimate off by 1.3-fold (0.12 log units), on the high side; low and high end bracket the measured number.
By their numbers in this assay, from the lowest: compound 3; then compounds 4, 2 and 1 (each within the scatter of the next).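

Swapping 4-hydroxypiperidin-1-yl for dimethylamino on a saturated chain carbon bound to an aromatic carbon gives a 3.2-fold higher number from compound 3 to compound 4 (0.51 log units; beyond the scatter) in this assay and thus reverses the drop seen earlier with the hydroxylated ring. Within the data shown here, the comparison with pyrrolidin-1-yl shows a 1.1-fold lower number from compound 2 to compound 4 (0.05 log units; within the scatter) and so leaves dimethylamino and pyrrolidin-1-yl indistinguishable here, which makes 4-hydroxypiperidin-1-yl the only one of the three groups that stands apart. Hydrogen in place of fluoro on an aromatic carbon gives a 2.0-fold lower number from compound 1 to compound 4 (0.29 log units; within the scatter) and so has no readable effect, while no measurement here explains the difference among the groups on the chain carbon.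

From the compounds shown here alone, it remains open whether the hydroxyl or the larger ring sets compound 3 apart. A piperidin-1-yl group at this place, the same ring without the hydroxyl, would separate the two.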